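This account rests on a few compounds, and the source may have more. Where it says the series, first, only, none or still open, it means among the compounds named here.

Working notes on the series. Compound 1 `COCc1noc([C@@H]2CC[C@@H](Nc3ncc4c(Br)nn(-c5ccc6ncccc6c5)c4n3)C2)n1` has no result recorded in an assay on SK-OV-3 cells for inhibition of eIF-2-alpha kinase GCN2 (Homo sapiens); a lower number here means a stronger inhibitor, a higher number a weaker inhibitor: for compound 1 the entry reads "nd" (no result reported). Among the compounds with values here, compound 2 `Brc1nn(-c2ccc3ncccc3c2)c2nc(N[C@@H]3CC[C@@H](c4ncc[nH]4)C3)ncc12` therefore carries the only number in the set; in this assay compound 2 gives 545 nM. Compound 3 `CNS(=O)(=O)[C@@H]1CC[C@@H](Nc2ncc3c(Br)nn(-c4ccc5ncccc5c4)c3n2)C1` differs from compound 2 in one place: methylsulfamoyl in place of 1H-imidazol-2-yl on a saturated ring carbon. Within the data shown here, no measured pair shows the effect of this exchange, so the expected change from a 1.7-fold higher number from compound 2 to compound 3 (0.22 log units; within the scatter) is a modest loss, possibly within the scatter. For compound 3 the expected value in this assay is 900 nM, within a range of 300 nM to 3000 nM.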

Compound 3, half-maximal inhibitory concentration: 106 nM
Compound 3: middle estimate off by 8.5-fold (0.93 log units), on the high side; the measured number lies below the stated range.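

On the saturated ring carbon, methylsulfamoyl in place of 1H-imidazol-2-yl gives a 5.1-fold lower number from compound 2 to compound 3 (0.71 log units; beyond the scatter) in this assay for this pair. The number at this position therefore depends on the group placed there, and a group with no ring gives the lower number here. Nothing at hand accounts for this step.

From the compounds shown here alone, it remains open whether methylsulfonyl, a carboxylic acid or a longer chain such as ethylsulfamoyl would match methylsulfamoyl on this carbon. A single pair also leaves open whether the step carries over to other cores.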